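Changing the aryl group at the end of the chain

This account rests on a few compounds, and the source may have more. Where it says the series, first, only, none or still open, it means among the compounds named here.

Three compounds sharing one core have been measured in a functional assay on SW-620 cells (Homo sapiens) for cytotoxicity, read by MTT assay, with stated times of 4 h and 72 h, tested at 2 uM; a higher number here means a weaker inhibitor, a lower number a stronger inhibitor:
Compound 1, `Cc1cc(Nc2ccc(C(=O)/C=C/c3ccccc3Cl)cc2)n2nc(SCc3nc4ccccc4[nH]3)nc2n1`, gives 680 nM.
Compound 2, `Cc1cc(Nc2ccc(C(=O)/C=C/c3ccc(C(F)(F)F)cc3)cc2)n2nc(SCc3nc4ccccc4[nH]3)nc2n1`, gives 1850 nM.
Compound 3, `Cc1cc(Nc2ccc(C(=O)/C=C/c3ccc(Br)cc3)cc2)n2nc(SCc3nc4ccccc4[nH]3)nc2n1`, gives 290 nM.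

Compound 3 stands lowest of the three and is thus the strongest inhibitor here. Its nearest neighbour is compound 1, separated by a 2.3-fold lower number from compound 1 to compound 3 (0.37 log units; beyond the scatter), and compound 2 lies furthest, separated by a 6.4-fold lower number from compound 2 to compound 3 (0.80 log units; beyond the scatter). The remaining measured step, a 2.7-fold higher number from compound 1 to compound 2 (0.43 log units; beyond the scatter), shows that the aryl group at the end of the chain on its own can move the number by modest amounts in either direction.

Compound 4, `COc1ccc(/C=C/C(=O)c2ccc(Nc3cc(C)nc4nc(SCc5nc6ccccc6[nH]5)nn34)cc2)cc1F`, differs from compound 3 in one place: 3-fluoro-4-methoxyphenyl in place of 4-bromophenyl on a double-bonded chain carbon bound to a double-bonded chain carbon. Within the data shown here, none of the measured steps involves the entering group, so they give no direction for this change; they only suggest the likely size of the move. Compound 3 is the lowest number seen, and a move upward is taken as somewhat more likely than a further drop. The expected step is a 2.1-fold higher number from compound 3 to compound 4 (0.32 log units; beyond the scatter), a modest rise in this assay. Compound 4 is therefore estimated at 600 nM, with a range from 200 nM to 2000 nM.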

Compound 4, half-maximal inhibitory concentration: 140 nM
Compound 4: the middle estimate sits 4.3-fold (0.63 log units) above what was measured; the whole stated range lies above it.
By their numbers in this assay, from the lowest: compound 4; then compound 3; then compound 1; then compound 2.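

In this assay the 3-fluoro-4-methoxyphenyl group takes the number lower than the 4-bromophenyl group did (a 2.1-fold lower number from compound 3 to compound 4 (0.32 log units; beyond the scatter)), so the best of the earlier aryl groups did not mark the floor at this position. Measured against the other two compounds, the same group widens the span that this single position covers (a 4.9-fold lower number from compound 1 to compound 4 (0.69 log units; beyond the scatter); a 13-fold lower number from compound 2 to compound 4 (1.12 log units; beyond the scatter)), and the second of these steps is the only large one so far, well beyond the modest moves seen before. No measurement at hand bears on what lies behind these steps.

The methoxy and the fluoro arrive together in compound 4, so the compounds shown cannot tell whether one of them accounts for the drop or whether both are needed; a phenyl ring carrying only the methoxy or only the fluoro would separate the two. Every group at this position is also a substituted phenyl ring, which leaves open how a phenyl ring bearing a dimethylamino group or a carboxylic acid would behave, or a saturated ring such as cyclohexyl.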